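This account rests on a few compounds, and the source may have more. Where it says the series, first, only, none or still open, it means among the compounds named here.

Compound 1, `CC1CCN(C2CCN(S(=O)(=O)c3cccnc3Cl)CC2)CC1`: in an ADME assay on HCT-116 cells (Homo sapiens) for cytotoxicity, read by CellTiter-Glo, with a stated time of 72 h (on this read-out lower numbers stand for stronger inhibition and higher numbers for weaker inhibition), compound 1 reaches only the assay limit > 10000 nM.
Compound 2, `Cc1ccc(-c2cccc(S(=O)(=O)N3CCC(N4CCC(C)CC4)CC3)c2)cc1`: in this assay compound 2 reaches only the assay limit > 5000 nM.
Compound 3, `CC1CCN(C2CCN(S(=O)(=O)c3cccc(-c4ccccc4)c3)CC2)CC1`: in this assay compound 3 reaches only the assay limit > 5000 nM.

Compound 3 therefore stands at a limit, not at a number, in this assay. Within the data shown here, the same holds for its two companions: one value sits at the limit of > 10000 nM in this assay, at which 1 of the 3 values shown sits, and two sit at the limit of > 5000 nM in this assay, at which 2 of the 3 values shown sit, so no compound here has a measured inhibitory concentration at all. Among the measured compounds shown here, the single step between measured compounds, a step that the two limits leave unreadable from compound 2 to compound 3, runs from one limit to another and so gives no size and no direction; all that can be said is that neither end showed activity within the tested range.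

Compound 4, `COc1cccc(S(=O)(=O)N2CCC(N3CCC(C)CC3)CC2)c1`, is the next compound to be tested. It differs from compound 3 by methoxy in place of phenyl on an aromatic carbon. For the measured compounds named here, no measured step touches this change, and the one step that exists is unreadable, so there is nothing here that would point toward a shift beyond the usual scatter in this assay. The expectation for compound 4 is therefore a step that the limit leaves unreadable from compound 3 to compound 4, that is, no real movement. The estimate for compound 4 in this assay is 8000 nM, expected to lie between 3000 nM and 20000 nM, most likely reported again as a limit rather than a number.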

Compound 4, half-maximal inhibitory concentration: > 5000 nM
Compound 4 gave a limit, no number; the forecaster's own chance of this, stated with the estimate: 80%; the middle value lies beyond the limit too.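

Compound 4 also stands at a limit, so its steps from compound 1, compound 2 and compound 3 cannot be read in this assay: the limit of > 5000 nM in this assay, at which 3 of the 4 values shown sit.

The compounds shown leave open what inhibitory concentration any of them actually has in this assay, and whether methoxy in place of phenyl makes any difference at all.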